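Adding a Second Chloro: Effect on Cell Tolerance

A few compounds are considered here, and "the series" means these few. Any claim that something is new, unique, unknown or untested is made for them only; others in the source may bear on it.

Three compounds have been measured in an ADME assay on MT4 cells (Homo sapiens) for cytotoxicity, read by MTT assay, with a stated time of 4 days; a lower number here means that less compound is tolerated, a higher number that more compound is tolerated:

Compound 1 `Cc1cc(-c2ccccc2)cc(C)c1Nc1ccnc(Nc2ccc(C#N)cc2)n1`: 4170 nM
Compound 2 `Cc1cc(-c2cccc(F)c2)cc(C)c1Nc1ccnc(Nc2ccc(C#N)cc2)n1`: 4120 nM
Compound 3 `Cc1cc(-c2cccc(Cl)c2)cc(C)c1Nc1ccnc(Nc2ccc(C#N)cc2)n1`: 2160 nM

Compound 3 shows the lowest of the three numbers, yet its distance to both of the others is small: the step of a 1.9-fold lower number from compound 1 to compound 3 (0.29 log units; within the scatter) and the step of a 1.9-fold lower number from compound 2 to compound 3 (0.28 log units; within the scatter) stay within the scatter, as does the step of a 1.0-fold lower number from compound 1 to compound 2 (0.01 log units; within the scatter). In effect, the three compounds are tolerated by the cells to about the same degree.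

Compound 4 `Cc1cc(-c2cc(Cl)cc(Cl)c2)cc(C)c1Nc1ccnc(Nc2ccc(C#N)cc2)n1` adds one further change to compound 3: chloro in place of hydrogen on an aromatic carbon. The measured steps that bear on this are the two in which a chloro first enters that ring, a 1.9-fold lower number from compound 1 to compound 3 (0.29 log units; within the scatter) and a 1.9-fold lower number from compound 2 to compound 3 (0.28 log units; within the scatter); each moved the number a little toward lower values, but neither rose above the scatter. A second chloro on the same ring is therefore expected to push the number slightly further in that direction, if at all, and the step of a 1.4-fold lower number from compound 3 to compound 4 (0.16 log units; within the scatter) is expected to remain within the scatter. Compound 4 is estimated at 1500 nM in this assay, with a likely range from 600 nM to 4000 nM.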

Compound 4, half-maximal cytotoxic concentration: 4290 nM
Compound 4: the middle estimate sits 2.9-fold (0.46 log units) below what was measured; measured number above the stated range.
By their numbers in this assay, from the lowest: compounds 3, 2, 1 and 4 (each within the scatter of the next).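

In this assay the step to the 3,5-dichlorophenyl group, a 2.0-fold higher number from compound 3 to compound 4 (0.30 log units; within the scatter), lies within the scatter, so a chloro on this aromatic carbon, meta to the chloro already present, produces no readable shift. The earlier compounds shown here left open whether more chloro on this ring would lead toward lower numbers, but this first doubly substituted ring shows no such shift, and both a 1.0-fold higher number from compound 2 to compound 4 (0.02 log units; within the scatter) and a 1.0-fold higher number from compound 1 to compound 4 (0.01 log units; within the scatter) also stay within the scatter. Across these four compounds, the ring therefore carries no, one or two halogen atoms without any trend that can be read from the numbers, and nothing available offers a reason for this flat picture.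

The compounds shown carry only hydrogen, fluoro and chloro on this ring, so they leave open whether an amine, a carboxylic acid or a longer chain in the same place would move the number beyond the scatter. From the compounds shown here alone, whether a bromo or a second fluoro on this ring would also stay within the scatter remains equally open.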